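Exchanging a 4-Fluorophenyl for a 2-Chlorophenyl Group

The source may hold more compounds than are shown below. What is called first, only, known or untested is meant among the compounds shown, and "the series" means these compounds.

Three compounds sharing one core have been examined in a functional assay, tested at 50 ug/mL; a lower number here means a weaker effect, a higher number a stronger effect of the compound at the concentration tested. Compound 1 `N#CC1=C(N)OC(c2c[nH]c3ccccc23)=C(C#N)C1c1cccc2ccccc12` carries a naphthalen-1-yl group on a saturated ring carbon and gives 4.7%. Compound 2 `N#CC1=C(N)OC(c2c[nH]c3ccccc23)=C(C#N)C1c1ccccc1` bears a phenyl group there and gives 14.4%, while compound 3 `N#CC1=C(N)OC(c2c[nH]c3ccccc23)=C(C#N)C1c1ccc(F)cc1`, with a 4-fluorophenyl group, gives 8.4%. Compound 3 thus holds the second highest of the three numbers; its nearest neighbour is compound 1, its furthest compound 2, and both gaps are within the usual scatter.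

The next compound, compound 4 `N#CC1=C(N)OC(c2c[nH]c3ccccc23)=C(C#N)C1c1ccccc1Cl`, differs from compound 3 in one place: 2-chlorophenyl in place of 4-fluorophenyl on a saturated ring carbon. Within the data shown here, the steps that bear on this change are those that alter the same saturated ring carbon. From compound 1 to compound 3 the readout moved by a number 3.7 percentage points higher from compound 1 to compound 3 (within the scatter), from compound 1 to compound 2 by a number 9.7 percentage points higher from compound 1 to compound 2 (within the scatter), and from compound 2 to compound 3 by a number 6 percentage points lower from compound 2 to compound 3 (within the scatter). Each of these lies within the scatter, so no step beyond the scatter is expected in this assay for compound 4, and the step from compound 3 to compound 4 is estimated at a number 0.6 percentage points higher from compound 3 to compound 4 (within the scatter). Compound 4 is expected to give about 9%, somewhere between 2% and 18%.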

Compound 4, a percentage reported as activity, at one concentration (the size of the read-out at that concentration, not a potency): 8.5%
Compound 4: middle estimate off by 0.5 percentage points, on the high side, within the range that was stated.
By their numbers in this assay, from the lowest: compounds 1, 3, 4 and 2 (each within the scatter of the next).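

In this assay, the exchange of 4-fluorophenyl for 2-chlorophenyl on the saturated ring carbon, which alters both the halogen and its place on the phenyl ring, gives a number 0.1 percentage points higher from compound 3 to compound 4 (within the scatter), so this double alteration leaves no readable mark. The two other comparisons with compound 4 stay within the scatter as well: chloro in place of hydrogen on the phenyl ring gives a number 5.9 percentage points lower from compound 2 to compound 4 (within the scatter), and 2-chlorophenyl in place of naphthalen-1-yl gives a number 3.8 percentage points higher from compound 1 to compound 4 (within the scatter), so a chloro-substituted phenyl ring joins the groups at this carbon that cannot be told apart in this assay. Nothing measured here offers an explanation for these small differences.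

Because the halogen and its place on the ring alter together, the compounds shown do not separate what each alteration contributes on its own. Going by these compounds, it also stays open whether a quite different group on this carbon, such as a phenyl ring carrying a carboxylic acid or an amine, or a longer alkyl chain in place of the ring, would move the read-out beyond the scatter.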